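Replacing azido with acetamido in compound 3

This account rests on a few compounds, and the source may have more. Where it says the series, first, only, none or still open, it means among the compounds named here.

In a functional assay on NCI-H460 cells (Homo sapiens) (a higher number here means that more compound is needed for the effect, a lower number that less compound is needed), compound 1 (`COc1cc(C2OC(c3cccc(N(C)C)c3)=NN2C(C)=O)cc(OC)c1OC`) reads 0.26 uM and compound 2 (`COC(=O)N1N=C(c2ccc(N(C)C)cc2)OC1c1cc(OC)c(OC)c(OC)c1`) reads 106 uM while compound 3 (`COc1cc(C2OC(c3ccc(N(C)C)cc3)=NN2C(=O)CN=[N+]=[N-])cc(OC)c1OC`) reads 0.53 uM and so holds the middle place of the three numbers, far under compound 2 and nearest to compound 1.

The next structure is compound 4 (`COc1cc(C2OC(c3ccc(N(C)C)cc3)=NN2C(=O)CNC(C)=O)cc(OC)c1OC`), with acetamido in place of azido on a saturated chain carbon bound to a carbonyl carbon.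

For the measured compounds named here, only one measured step bears on that carbonyl: a 200-fold lower number from compound 2 to compound 3 (2.30 log units; beyond the scatter) is large, with azidomethyl in place of methoxy on a carbonyl carbon. Going by the values given here, it shows that the number can move strongly with the group there, but no measured pair changes azido alone. Compound 1 carries a different group on the carbonyl and differs elsewhere as well, so it is only a loose guide. The carbonyl and the saturated chain carbon remain in compound 4, so a much smaller change than that step is expected. Compound 3 already stands low at 0.53 uM among the three, so a modest rise in this assay is the likelier direction. The expected step is a 2.8-fold higher number from compound 3 to compound 4 (0.45 log units; beyond the scatter) and it remains an uncertain estimate. Compound 4 is estimated at 1.5 uM with a range of 0.3 uM to 8 uM as the expected span.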

Compound 4, concentration for half-maximal effect: 0.48 uM
Compound 4: middle estimate off by 3.1-fold (0.49 log units), on the high side; the measured number falls inside the stated range.
By their numbers in this assay, from the lowest: compounds 1, 4 and 3 (each within the scatter of the next, the first and the last beyond it); then compound 2.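

In this assay, for the compounds shown here, the step of a 1.1-fold lower number from compound 3 to compound 4 (0.04 log units; within the scatter) is the first reading of a change confined to the group on a saturated chain carbon bound to a carbonyl carbon, and azido and acetamido cannot be told apart here, even though acetamido brings a hydrogen-bond donor that azido lacks. The large step seen earlier with azidomethyl recurs with acetamidomethyl (a 220-fold lower number from compound 2 to compound 4 (2.34 log units; beyond the scatter)), so at this carbonyl both substituted methyl groups stand far from methoxy, and that contrast no longer rests on a single pair. No measured property of these groups accompanies the numbers, and nothing at hand accounts for this result.

Still open, from the compounds shown here alone, is whether the same insensitivity holds for a free primary amine or a carboxylic acid on that saturated chain carbon, or for a longer chain bearing the acetamido group. Compound 1 differs from compound 3 and from compound 4 in more than one place, so the separate contributions of its acetyl group and of the place of its dimethylamino group cannot be read from these compounds.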